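Three analogues level in this assay and a fourth to come

The compounds below may be only part of what the source reports. "The series", "measured", "known", "first", "only" and "open" are said of these compounds alone.

Three compounds built on one shared core were tested in an assay on CHO cells for displacement of a labelled ligand from adenosine receptor A1 (Homo sapiens), read by scintillation counting, with a stated time of 120 min, tested at 10 uM; on this read-out higher numbers stand for more inhibition at the one concentration tested (going by the name of the read-out) and lower numbers for less inhibition. Compound 1 `Nc1scc(CN2CCN(c3ccc(OC(F)(F)F)cc3)CC2)c1C(=O)c1ccc(Cl)cc1` gives 0%. Compound 2 `Nc1scc(CN2CCN(c3cccnc3)CC2)c1C(=O)c1ccc(Cl)cc1` gives 0%. Compound 3 `Nc1scc(CN2CCN(c3cccc(F)c3F)CC2)c1C(=O)c1ccc(Cl)cc1` gives 0%. Compound 2 thus stands level with compound 1 and compound 3: the steps of no change at the digits printed from compound 1 to compound 2 (within the scatter), no change at the digits printed from compound 2 to compound 3 (within the scatter) and no change at the digits printed from compound 1 to compound 3 (within the scatter) all lie within the scatter. Compound 4 `Nc1scc(CN2CCN(c3ccc(Cl)c(Cl)c3)CC2)c1C(=O)c1ccc(Cl)cc1` differs from compound 2 in one place: 3,4-dichlorophenyl in place of pyridin-3-yl on an amine nitrogen in a ring. The three measured steps each exchanged the group on the same ring nitrogen and left the inhibition unchanged, so no step beyond the scatter is expected here either, namely no change at the digits printed from compound 2 to compound 4 (within the scatter). Compound 4 is accordingly estimated at 0%, with a range from -10% to 10%.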

Compound 4, a percentage reported as inhibition, at one concentration (the size of the read-out at that concentration, not a potency): 1%
Estimate against measurement, compound 4: 1 percentage points below; the range from low to high includes it.
By their numbers in this assay, from the lowest: compounds 1, 2, 3 and 4 (each within the scatter of the next).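

Placing 3,4-dichlorophenyl on this ring nitrogen gives a number 1 percentage points higher from compound 2 to compound 4 (within the scatter), a number 1 percentage points higher from compound 3 to compound 4 (within the scatter) and a number 1 percentage points higher from compound 1 to compound 4 (within the scatter) in this assay. Chlorine on the aromatic ring therefore joins the other aromatic groups tried here, none of which separates from the rest on this read-out. No supporting data bear on this flat result.

As far as these compounds go, whether a non-aromatic group on this ring nitrogen, such as an acetyl group or a longer alkyl chain, would shift the number remains open. So does the effect of changes elsewhere on the shared core.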